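Adding a Nitro Group and Cytotoxicity in Macrophage Cells

The compounds below may be only part of what the source reports. "The series", "measured", "known", "first", "only" and "open" are said of these compounds alone.

Compound 1 `COc1cc(NC(=O)c2ccc(Cl)cc2)ccc1NS(C)(=O)=O` and compound 3 `CCS(=O)(=O)Nc1ccc(NC(=O)c2ccc(Cl)cc2)cc1F` have different cores; the difference between the two cores is not broken down here. In an ADME assay on RAW264.7 cells (Mus musculus) for cytotoxicity, read by MTT assay, with a stated time of 48 h (a higher number here means a weaker inhibitor, a lower number a stronger inhibitor), compound 1 gives 70000 nM. Compound 3 gives 152000 nM in this assay. Compound 2 `COc1cc(NC(=O)c2ccc(Cl)c([N+](=O)[O-])c2)ccc1NS(C)(=O)=O` differs from compound 1 by nitro in place of hydrogen on an aromatic carbon. For compound 2, this assay reports only a limit, > 250000 nM. This makes an at least 3.5-fold higher number from compound 1 to compound 2 (0.55 log units; beyond the scatter), and because of the limit of > 250000 nM in this assay, at which 1 of the 3 values shown sits, the true size of that step is not known. Compound 4 `CCS(=O)(=O)Nc1ccc(NC(=O)c2ccc(Cl)c([N+](=O)[O-])c2)cc1F` carries the same kind of change relative to compound 3, namely (nitro in place of hydrogen on an aromatic carbon), at a place described in the same words. The expected step in this assay is a 3.0-fold higher number from compound 3 to compound 4 (0.47 log units; beyond the scatter), resting on an at least 3.5-fold higher number from compound 1 to compound 2 (0.55 log units; beyond the scatter). Compound 4 is therefore expected to give about 450000 nM, between 200000 nM and 1200000 nM, with a real chance that only a limit is reported.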

Compound 4, half-maximal inhibitory concentration: 198000 nM
Compound 4: middle estimate off by 2.3-fold (0.36 log units), on the high side; the measured number lies below the stated range.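

In this assay the change gives a 1.3-fold higher number from compound 3 to compound 4 (0.11 log units; within the scatter), so on this core the nitro group makes no clear difference, and the change does not carry over at the size seen on the core of compound 1: the same change on two cores in this assay, an at least 3.5-fold higher number (0.55 log units; beyond the scatter) from compound 1 to compound 2 and a 1.3-fold higher number (0.11 log units; within the scatter) from compound 3 to compound 4, at least 2.7-fold (0.43 log units) apart, beyond the scatter of two such steps. Compound 2 gives > 250000 nM, which is a limit, so the full size of the earlier step is not known: the limit of > 250000 nM in this assay, at which 1 of the 4 values shown sits. Two pairs show that the step can differ between cores, but they cannot show which difference between the cores sets its size.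

The compounds shown leave open whether another group in the same place, such as an amine or a carboxylic acid, would give matching steps on both cores.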